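Amide-nitrogen aryl swap: compound 3 to compound 4

This account rests on a few compounds, and the source may have more. Where it says the series, first, only, none or still open, it means among the compounds named here.

Working notes. The shared core is constant; the compounds differ only in the group on the amide nitrogen. Compound 1 `COc1cccc(C(C)NC(=O)COc2cc(C(F)(F)F)c3c(-c4ccccc4)nn(C)c3n2)c1` gives 20 nM in a functional assay on isolated protein for antagonist activity at Orexin/Hypocretin receptor type 1 (Homo sapiens), read by fluorescence, FLIPR and calcium flux, with a stated time of 1 h; a higher number here means a weaker inhibitor, a lower number a stronger inhibitor. Compound 2 `CC(NC(=O)COc1cc(C(F)(F)F)c2c(-c3ccccc3)nn(C)c2n1)c1ccccn1` gives 2670 nM in this assay, and compound 3 `CC(NC(=O)COc1cc(C(F)(F)F)c2c(-c3ccccc3)nn(C)c2n1)c1cccnc1` gives 970 nM. Compound 3 thus stands second highest of the three numbers: a 2.8-fold lower number from compound 2 to compound 3 (0.44 log units; beyond the scatter), whereas a 49-fold higher number from compound 1 to compound 3 (1.69 log units; beyond the scatter).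

Compound 4 `COc1ccc(CNC(=O)COc2cc(C(F)(F)F)c3c(-c4ccccc4)nn(C)c3n2)cc1` carries 4-methoxybenzyl in place of 1-(pyridin-3-yl)ethyl on an amide-type nitrogen. The step that bears on it is the one in the opposite sense, a 49-fold higher number from compound 1 to compound 3 (1.69 log units; beyond the scatter), which shows what leaving a methoxyphenyl for a pyridin-3-yl cost. Compound 4 returns to a methoxyphenyl, but as 4-methoxybenzyl rather than the 3-methoxyphenyl of compound 1, and without the methyl on the saturated chain carbon. Among the measured compounds shown here, no measured pair covers either of those two further changes, so a full return to the number of compound 1 cannot be assumed. A clearly lower number is nonetheless expected, an 8.1-fold lower number from compound 3 to compound 4 (0.91 log units; beyond the scatter). Compound 4 is estimated at 120 nM, within 25 nM to 600 nM.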

Compound 4, inhibition constant: 800 nM
Beside the measured number, compound 4's estimate is 6.7-fold (0.82 log units) below it, and the stated range ends below it.
By their numbers in this assay, from the lowest: compound 1; then compounds 4 and 3 (each within the scatter of the next); then compound 2.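

In this assay, a methoxy-bearing aromatic ring on the amide-type nitrogen is not enough to hold the number of compound 1, since 4-methoxybenzyl gives a 40-fold higher number from compound 1 to compound 4 (1.60 log units; beyond the scatter). The same group shows a 1.2-fold lower number from compound 3 to compound 4 (0.08 log units; within the scatter) and a 3.3-fold lower number from compound 2 to compound 4 (0.52 log units; beyond the scatter), so an aromatic ring of carbon only does not, in this form, separate it from the 1-(pyridin-3-yl)ethyl group. Nothing measured on these compounds accounts for these steps.

Going by these compounds, compound 4 departs from compound 1 in two ways at once, with the methoxy group placed as in 4-methoxybenzyl and the methyl on the saturated chain carbon gone, so the share of each in that step stays open. Also open, on these data alone, is how 3-methoxybenzyl, 1-(4-methoxyphenyl)ethyl or the longer 2-(3-methoxyphenyl)ethyl chain would read on the amide-type nitrogen.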